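Swapping the aryl group on a weakly active triazine ether

The compounds below may be only part of what the source reports. "The series", "measured", "known", "first", "only" and "open" are said of these compounds alone.

Of the compounds shown here, three have been tested in a functional assay on A549 cells (Homo sapiens) for antiproliferative activity, read by MTT assay, with a stated time of 72 h; on this read-out higher numbers stand for weaker inhibition and lower numbers for stronger inhibition. Compound 1, with structure `CC(C)(C)c1ccc(OCCCON2C(N)=NC(N)=NC23CCSCC3)cc1`, gives 1 nM. Compound 3, `NC1=NC2(CCSCC2)N(OCCCOc2cccc(Cl)c2Cl)C(N)=N1`, gives 1 nM. Compound 2, `NC1=NC2(CCOCC2)N(OCCCOc2ccccc2Cl)C(N)=N1`, gives 2700 nM, the highest number of the three and therefore the weakest inhibitor in this set; its nearest neighbour on the numbers is compound 1, and the gap to both compound 1 and compound 3 lies far beyond the scatter. Among the compounds with values here, compound 2 also carries a different core from compound 1 and compound 3, so the aryl group and the core change together and no single step between measured compounds can be isolated.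

Compound 4, `NC1=NC2(CCOCC2)N(OCCCOc2ccc(Br)cc2)C(N)=N1`, keeps the core of compound 2 and differs from it in one place: 4-bromophenyl in place of 2-chlorophenyl on an oxygen on a saturated carbon. Within the data shown here, with no measured step of this kind to lean on, the expected change in this assay is a modest move toward stronger inhibition, of uncertain size, and a result within the scatter would not surprise. The step from compound 2 to compound 4 is estimated at a 3.4-fold lower number from compound 2 to compound 4 (0.53 log units; beyond the scatter), so compound 4 is expected to give about 800 nM, between 80 nM and 8000 nM.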

Compound 4, half-maximal inhibitory concentration: 280 nM
Beside the measured number, compound 4's estimate is 2.9-fold (0.46 log units) above it; low and high end bracket the measured number.
By their numbers in this assay, from the lowest: compounds 1 and 3 (each within the scatter of the next); then compound 4; then compound 2.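

In this assay, within the data shown here, with the core of compound 2 held constant, placing 4-bromophenyl in place of 2-chlorophenyl gives a 9.6-fold lower number from compound 2 to compound 4 (0.98 log units; beyond the scatter) and provides the first measured step in which only the aryl group changes. This shows that the aryl group can shift the number beyond the scatter without any change to the core, although the halogen and its location on the ring change together, so their contributions cannot be separated. Nothing available explains why the number moves.

The compounds shown leave open whether the same swap would have a similar effect on the core of compound 1. They also leave open how this position would respond to an aryl ring carrying an amine or a carboxylic acid, and whether a longer chain would change the result.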